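The compounds below may be only part of what the source reports. "The series", "measured", "known", "first", "only" and "open" are said of these compounds alone.

In an ADME assay (Fibroblast) for cytotoxicity, with Homo sapiens as the target (a lower number here means a stronger inhibitor, a higher number a weaker inhibitor), compound 2 `N#Cc1cn(COCCO)c2ncnc(N)c12` gives only a limit, > 100000 nM. Compound 1 `CC(=O)OCCOCn1cc(C#N)c2c(N)ncnc21` likewise gives only a limit in this assay, > 100000 nM. Compound 3 `N#Cc1cnc2n(COCCO)cnc(N)c1-2` also gives only a limit, > 320000 nM. Within the data shown here, the single step between measured compounds, a step that the two limits leave unreadable from compound 1 to compound 2, hydrogen in place of acetyl on an oxygen on a saturated carbon, cannot be sized because the limit of > 100000 nM in this assay, at which 2 of the 3 values shown sit, holds both of its ends, while the limit of > 320000 nM in this assay, at which 1 of the 3 values shown sits, covers the third compound.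

Compound 4 `COC(=N)c1cn(COCCO)c2ncnc(N)c12` differs from compound 2 by a group of 4 heavy atoms (2 carbon, 1 nitrogen, 1 oxygen; no ring) in place of a group of 2 heavy atoms (1 carbon, 1 nitrogen; no ring), on an aromatic carbon. Among the measured compounds shown here, no measured step touches this change, and the one step that exists lies elsewhere and is unreadable. The step that the limit leaves unreadable from compound 2 to compound 4 is therefore expected to be none beyond the scatter. Compound 4 is expected at 150000 nM, within a range from 50000 nM to 500000 nM.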

Compound 4, half-maximal inhibitory concentration: > 100000 nM
Compound 4 gave a limit, no number (the forecaster's own chance of this, stated with the estimate: 80%); the middle value lies beyond the limit too.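

Compound 2 and compound 4 both end at a limit, so the step between them cannot be read, because the two share one ceiling: the limit of > 100000 nM in this assay, at which 3 of the 4 values shown sit.

The compounds shown leave open whether any change to the shared core would give a measurable number in this assay.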